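Swapping a Hydroxyalkyl Amide Substituent for 1,3-Dicarboxypropyl

This account rests on a few compounds, and the source may have more. Where it says the series, first, only, none or still open, it means among the compounds named here.

Compound 1 `CCn1c(C(=O)N[C@@H](C)CO)ccc1C(CC)(CC)c1ccc(OCS(=O)(=O)c2ccccc2)c(C)c1` gives 10800 nM in a functional assay on MCF7 cells (Homo sapiens) for antiproliferative activity, read by MTT assay, with a stated time of 24 h; on this read-out lower numbers stand for stronger inhibition and higher numbers for weaker inhibition.
Compound 2 `CCn1c(C(=O)N[C@H](CO)C(C)C)ccc1C(CC)(CC)c1ccc(OCS(=O)(=O)c2ccccc2)c(C)c1` gives 25500 nM in this assay.
Compound 3 `CCn1c(C(=O)N[C@H](CO)CCCO)ccc1C(CC)(CC)c1ccc(OCS(=O)(=O)c2ccccc2)c(C)c1` gives 31400 nM in this assay.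

All three share the same core and differ only in the group carried on the amide-type nitrogen. Compound 3 has the highest of the three numbers in this assay: against compound 2 its value lies within the scatter, while compound 1 sits clearly lower, with a 2.9-fold higher number from compound 1 to compound 3 (0.46 log units; beyond the scatter). The other measured steps are a 2.4-fold higher number from compound 1 to compound 2 (0.37 log units; beyond the scatter) and a 1.2-fold higher number from compound 2 to compound 3 (0.09 log units; within the scatter).

Compound 4 `CCn1c(C(=O)N[C@H](CCC(=O)O)C(=O)O)ccc1C(CC)(CC)c1ccc(OCS(=O)(=O)c2ccccc2)c(C)c1` is the next step. Relative to compound 3 the change is a group of 9 heavy atoms (5 carbon, 4 oxygen; no ring) in place of a group of 7 heavy atoms (5 carbon, 2 oxygen; no ring), on an amide-type nitrogen. Going by the values given here, none of the measured steps involve such an acid-bearing group; they only show that enlarging the side chain on that nitrogen, as in a 2.4-fold higher number from compound 1 to compound 2 (0.37 log units; beyond the scatter) and a 2.9-fold higher number from compound 1 to compound 3 (0.46 log units; beyond the scatter), brought modestly higher numbers, and that two different larger chains, compared in a 1.2-fold higher number from compound 2 to compound 3 (0.09 log units; within the scatter), gave much the same result. On that basis a further, at most modest, rise in the number is expected, with compound 4 estimated at 45000 nM (range 15000 nM to 120000 nM), which is expected to correspond to a 1.4-fold higher number from compound 3 to compound 4 (0.16 log units; within the scatter).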

Compound 4, half-maximal inhibitory concentration: > 50000 nM
Compound 4 was reported as a limit (the forecaster's own chance of this, stated with the estimate: 25%); middle value at least 1.1-fold (0.04 log units) from the limit.
By their numbers in this assay, from the lowest: compound 1; then compounds 2 and 3 (each within the scatter of the next). At a limit, above all of these: compound 4.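

Compound 4, which carries 1,3-dicarboxypropyl on the amide-type nitrogen, is recorded in this assay only as a limit, > 50000 nM. Going by these compounds alone, this is the first acid-bearing group at this position, and it gives a result clearly apart from the 1-(hydroxymethyl)ethyl chain, with an at least 4.6-fold higher number from compound 1 to compound 4 (0.66 log units; beyond the scatter). The other two steps, an at least 1.9-fold higher number from compound 2 to compound 4 (0.29 log units; that floor lies within the scatter) and an at least 1.5-fold higher number from compound 3 to compound 4 (0.20 log units; that floor lies within the scatter), have floors that lie within the scatter, so the limit alone does not separate the new chain from the other hydroxyl-bearing chains, even though the true gap could be wider.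

The compounds shown leave open where the true value of compound 4 lies and whether a chain ending in a single carboxylic acid, or the methyl esters of both acids, would return a measurable number in this assay. They also cannot separate the effect of the carboxylic acid groups from that of the chain carrying them, a question that an amine at the end of the same chain could help to address.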